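This account rests on a few compounds, and the source may have more. Where it says the series, first, only, none or still open, it means among the compounds named here.

In an ADME assay on Huh-7 cells (Homo sapiens) for cytotoxicity, with a stated time of 72 h (a lower number here means that less compound is tolerated, a higher number that more compound is tolerated), compound 2 `CC(C)CCn1nc(-c2cccs2)c(O)c(C2=NS(=O)(=O)c3cc(S(C)(=O)=O)ccc3N2)c1=O` has no usable result, only the entry "not determined" (no result reported). The nearest reading comes from compound 1 `CC(C)CCn1nc(-c2cccs2)c(O)c(C2=NS(=O)(=O)c3cc(NS(=O)(=O)C(C)C)ccc3N2)c1=O`, which gives > 1000 nM, a limit and not a number. Compound 3 `CC(C)CCn1nc(-c2cccs2)c(O)c(C2=NS(=O)(=O)c3cc(S(N)(=O)=O)ccc3N2)c1=O` has yet to be measured. The change is methylsulfonyl to sulfamoyl, amino in place of methyl on a sulfonyl sulfur. Among the measured compounds shown here, no measured step gauges this change, so the expectation is weak: no shift beyond the usual scatter in this assay, in either direction. The estimate for compound 3 is 5000 nM, with an expected range of 1000 nM to 25000 nM.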

Compound 3, half-maximal cytotoxic concentration: > 33000 nM
Compound 3 was reported as a limit; the forecaster's own chance of this, stated with the estimate: 80%; middle value at least 6.6-fold (0.81 log units) from the limit.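

In this assay, among the compounds shown here, compound 1 and compound 3 are both reported only as limits, so no step between them can be read. The compounds shown leave open whether sulfamoyl differs from methylsulfonyl or (isopropylsulfonyl)amino at all in this assay.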